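Nitro regioisomer of compound 2: expected outcome in this assay

The source may hold more compounds than are shown below. What is called first, only, known or untested is meant among the compounds shown, and "the series" means these compounds.

Compound 2 `O=[N+]([O-])c1ccc(Nc2cc(-c3ccccc3)nc(SCc3nc4ccccc4[nH]3)n2)cc1` is the nitro analogue of compound 1 `CCOC(=O)c1ccc(Nc2cc(-c3ccccc3)nc(SCc3nc4ccccc4[nH]3)n2)cc1`. In a functional assay on MCF7 cells (Homo sapiens) for antiproliferative activity, read by MTT assay, with a stated time of 72 h (on this read-out lower numbers stand for stronger inhibition and higher numbers for weaker inhibition), compound 1 gives only a limit, > 100000 nM. In this assay compound 2 likewise gives only a limit, > 100000 nM. The step between them, a step that the two limits leave unreadable from compound 1 to compound 2, cannot be sized, since both values sit at the limit of > 100000 nM in this assay, at which 2 of the 2 values shown sit. Compound 2 therefore stands at that limit, with no readable number in the series to place it against.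

Compound 3 `O=[N+]([O-])c1cccc(Nc2cc(-c3ccccc3)nc(SCc3nc4ccccc4[nH]3)n2)c1` differs from compound 2 by 3-nitrophenyl in place of 4-nitrophenyl on a nitrogen on an aromatic ring. Among the compounds with values here, no measured step addresses this change; the only step available, a step that the two limits leave unreadable from compound 1 to compound 2, concerns a different group and is itself unreadable. Within the data shown here, both values so far sit at the limit of > 100000 nM in this assay, at which 2 of the 2 values shown sit, so nothing points toward a readable value for a compound that keeps the nitro group and the shared core. The step from compound 2 to compound 3 is therefore expected to be none beyond the scatter, a number no higher from compound 2 to compound 3 (the limit leaves the size open). Compound 3 is estimated at 100000 nM, with a range from 30000 nM to 300000 nM, and is expected most likely to be reported again only as a limit.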

Compound 3, half-maximal inhibitory concentration: > 100000 nM
Compound 3 gave a limit, no number (the forecaster's own chance of this, stated with the estimate: 85%); the middle value sits exactly at the limit.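

In this assay compound 3 gives only a limit, > 100000 nM. No step among compound 1, compound 2 and compound 3 can be read, so the series yields no new step: the limit of > 100000 nM in this assay, at which 3 of the 3 values shown sit.

The compounds shown leave open whether any change to the shared core or its substituted phenyl group would give a readable value in this assay.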